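The compounds below may be only part of what the source reports. "The series", "measured", "known", "first", "only" and "open" are said of these compounds alone.

Working notes on the series. Compound 1 `COc1c(C)ccc2c1CCC2c1ncc[nH]1` is the reference point. Among the compounds with values here, in a functional assay on CHO cells for agonist activity at Alpha-1A adrenergic receptor (Homo sapiens), read by FLIPR and calcium flux (a lower number here means that less compound is needed, a higher number that more compound is needed for the effect), compound 1 gives 167 nM, the highest of the two numbers measured so far; its nearest neighbour is compound 2 `Cc1ccc2c(c1NS(C)(=O)=O)CCC2c1ncc[nH]1`, which in this assay gives 33 nM. Within the data shown here, the only measured step in the set, a 5.1-fold lower number from compound 1 to compound 2 (0.70 log units; beyond the scatter), concerns a change at a different group from the one now at hand.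

Compound 3 `COc1c(Cl)ccc2c1CCC2c1ncc[nH]1` is not yet measured. It differs from compound 1 by chloro in place of methyl on an aromatic carbon. Among the measured compounds shown here, no measured step bears directly on this change: the step from compound 1 to compound 2 swaps the methoxy for a methanesulfonamido and leaves the methyl untouched, whereas here the methoxy stays and the methyl is replaced. With nothing in the data to anchor a direction, the expectation is a step that stays within the scatter, in either direction. The estimate for compound 3 in this assay is therefore 150 nM, with a range from 50 nM to 450 nM. That corresponds to an expected 1.1-fold lower number from compound 1 to compound 3 (0.05 log units; within the scatter).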

Compound 3, half-maximal effective concentration: 451 nM
Compound 3: the middle estimate sits 3.0-fold (0.48 log units) below what was measured; the measured number lies above the stated range.
By their numbers in this assay, from the lowest: compound 2; then compound 1; then compound 3.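

Within the data shown here, the step of a 2.7-fold higher number from compound 1 to compound 3 (0.43 log units; beyond the scatter) in this assay is the first measured change at the aromatic carbon ortho to a methoxy group, a place that the only earlier step left untouched. With the methoxy kept, chloro in place of methyl moves the number beyond the scatter, so this position is not indifferent to the exchange of these two groups, and of the pair, methyl carries the lower number. Nothing available explains the size or direction of this step.

The compounds shown leave open how other groups at this position would read in this assay, such as an ethyl chain, a hydroxyl or an amine, so two groups give a comparison but not yet a trend. They also leave open whether the step seen with the methoxy in place would carry over to compounds with the methanesulfonamido of compound 2, where chloro in place of methyl could give a step of a different size or direction.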